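The source may report more compounds than this note shows. Statements on the series, on what has been measured and on what is new or still open speak of the compounds shown alone.

For the measured compounds named here, in an assay on isolated protein for agonist activity at Bile acid receptor (Homo sapiens), read by FRET (a lower number here means that less compound is needed, a higher number that more compound is needed for the effect), compound 2 `O=C(O)c1ccc(C2CC2c2ccc(OCc3c(-c4c(Cl)cccc4Cl)noc3C3CC3)cc2Cl)cn1` gives 66 nM and holds the lowest of the two numbers measured so far; its nearest neighbour, compound 1 `O=C(O)c1cccc([C@H]2C[C@@H]2c2ccc(OCc3c(-c4c(Cl)cccc4Cl)noc3C3CC3)cc2Cl)c1`, gives 219 nM in this assay. Going by the values given here, the one measured step, a 3.3-fold lower number from compound 1 to compound 2 (0.52 log units; beyond the scatter), is the only comparison available.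

Compound 3 `O=C(O)c1cccc([C@@H]2C[C@H]2c2ccc(OCc3c(-c4c(Cl)cccc4Cl)noc3C3CC3)cc2Cl)c1` has not been measured in this assay. Relative to compound 2 it differs in one place: 2-(3-carboxyphenyl)cyclopropyl in place of 2-(6-carboxypyridin-3-yl)cyclopropyl on an aromatic carbon. This is the exact reverse of the measured change, with the added point that the entering group carries two defined stereocentres, whereas compound 1 carries the same group with its stereocentres set the other way. Since the step from compound 1 to compound 2 lowered the number modestly, reversing it should raise the number by a similar amount, though the different arrangement at the stereocentres makes the outcome less certain and widens the range. Compound 3 is therefore expected to give about 220 nM in this assay, between 50 nM and 1000 nM, a step of a 3.3-fold higher number from compound 2 to compound 3 (0.52 log units; beyond the scatter).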

Compound 3, half-maximal effective concentration: 18 nM
The estimate for compound 3 lay 12-fold (1.09 log units) above the measured number, and the stated range ends above it.
By their numbers in this assay, from the lowest: compound 3; then compound 2; then compound 1.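

In this assay, inverting both stereocentres of the 2-(3-carboxyphenyl)cyclopropyl group gives a 12-fold lower number from compound 1 to compound 3 (1.09 log units; beyond the scatter), the largest step among these compounds, and this gap can be assigned to configuration alone: the fact that compounds 1 and 3 differ only in the configuration as drawn. The comparison with the 2-(6-carboxypyridin-3-yl)cyclopropyl group also changes, since the earlier step favoured that group over the mirror-image form in compound 1, whereas the new one, a 3.7-fold lower number from compound 2 to compound 3 (0.56 log units; beyond the scatter), favours the 2-(3-carboxyphenyl)cyclopropyl group in the configuration of compound 3. The standing of the two groups at this position therefore depends on which configuration is compared. Compound 2 is drawn without defined stereocentres. Neither of its steps isolates the exchange of the aromatic rings.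

The compounds shown leave open how the separate defined forms of the 2-(6-carboxypyridin-3-yl)cyclopropyl group would compare with each other and with compound 3. They also leave open whether the carboxylic acid could give way to a tetrazole or a primary amide while the configuration of compound 3 is kept.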